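The source may hold more compounds than are shown below. What is called first, only, known or untested is meant among the compounds shown, and "the series" means these compounds.

Measured compounds and their values:
- compound 1, `CCOC(=O)C1=C(Nc2ccccc2)S/C(=C\c2ccc(C(=O)O)cc2)C1=O`, gives 11.6% in a functional assay on A549 cells (Homo sapiens) for inhibition, read by MTT assay, with a stated time of 72 h, tested at 10 uM; a lower number here means less inhibition, a higher number more inhibition at the concentration tested (going by the name of the read-out)
- compound 2, `CCOC(=O)C1=C(Nc2ccc(OC)cc2)S/C(=C\c2ccc[nH]2)C1=O`, sits at a limit of this assay, < 10%
- compound 3, `CCOC(=O)C1=C(Nc2ccccc2)S/C(=C\c2ccc(C(=O)OCC)[nH]2)C1=O`, sits at a limit of this assay, < 10%

For the measured compounds named here, compound 1 therefore holds the only plain number among the three; the other two values are limits, namely (the limit of < 10% in this assay, at which 2 of the 3 values shown sit). All three results are low, and nothing here separates them beyond the usual scatter. Compound 4, `CCOC(=O)C1=C(Nc2ccccc2)S/C(=C\c2cc3cccnc3[nH]2)C1=O`, has not yet been tested in this assay. It differs from compound 1 by a group of 9 heavy atoms (7 carbon, 2 nitrogen; one five-membered aromatic ring with 1 hetero atom, one six-membered aromatic ring with 1 hetero atom) in place of a group of 9 heavy atoms (7 carbon, 2 oxygen; one six-membered aromatic ring of carbon only), on a double-bonded chain carbon bound to a double-bonded ring carbon. Going by the values given here, with no measured step to scale from, the expectation is no change beyond the scatter in this assay. Compound 4 is estimated at 12%, within 0% to 35%. The expected step is a number 0.4 percentage points higher from compound 1 to compound 4 (within the scatter), inside the scatter.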

Compound 4, a percentage reported as inhibition, at one concentration (the size of the read-out at that concentration, not a potency): 16.7%
The estimate for compound 4 lay 4.7 percentage points below the measured number; the measured number falls inside the stated range.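

In this assay, replacing the 4-carboxyphenyl on the double-bonded chain carbon with the group of compound 4, which has a five-membered and a six-membered aromatic ring, gives a number 5.1 percentage points higher from compound 1 to compound 4 (within the scatter). This place on the shared core therefore takes a very different aromatic group, one with ring nitrogens instead of an all-carbon ring and a carboxylic acid, without a clear change in the reading. Readings stay low across the set: the limit of < 10% in this assay, at which 2 of the 4 values shown sit.

On these data alone, whether an amine or a longer chain in this place would lift the reading clear of the scatter remains open. So does whether changes elsewhere on the shared core would do so.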